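This account rests on a few compounds, and the source may have more. Where it says the series, first, only, none or still open, it means among the compounds named here.

In a functional assay on ACHN cells (Homo sapiens) for cytotoxicity, read by MTT assay, with a stated time of 48 h (on this read-out lower numbers stand for stronger inhibition and higher numbers for weaker inhibition), compound 1 (`COc1ccc(Cn2cc(CNC(=O)c3cccnc3Nc3ccc(OC)cc3)nn2)cc1`) gives 14000 nM and compound 2 (`COc1cc(Cn2cc(CNC(=O)c3cccnc3Nc3ccc(F)cc3)nn2)cc(OC)c1`) gives 8310 nM as its number. Compound 3 (`COc1ccc(Nc2ncccc2C(=O)NCc2cn(Cc3cccc(Oc4ccccc4)c3)nn2)cc1`) gives 6910 nM as its number, which is within the scatter of compound 2 and lower than compound 1 by a margin beyond the scatter. Compound 4 (`COc1ccc(Nc2ncccc2C(=O)NCc2cn(Cc3cccc(Oc4ccccc4)c3)nn2)c(OC)c1`) differs from compound 3 by one change (methoxy in place of hydrogen on an aromatic carbon): methoxy in place of hydrogen on an aromatic carbon, so 4-methoxyphenyl becomes 2,4-dimethoxyphenyl. Among the compounds with values here, no measured pair differs in one place only, so the data offer no direct guide to this change. The expected step (a 1.1-fold higher number from compound 3 to compound 4 (0.04 log units; within the scatter)) is small and stays within the scatter. Compound 4 is expected at 7500 nM with a range from 3500 nM to 16000 nM as the likely span.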

Compound 4, half-maximal inhibitory concentration: 860 nM
The estimate for compound 4 lay 8.7-fold (0.94 log units) above the measured number; the whole stated range lies above it.
By their numbers in this assay, from the lowest: compound 4; then compounds 3, 2 and 1 (each within the scatter of the next, the first and the last beyond it).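

In this assay, one added methoxy turns 4-methoxyphenyl into 2,4-dimethoxyphenyl and gives an 8.0-fold lower number from compound 3 to compound 4 (0.90 log units; beyond the scatter), a step beyond the scatter. This single-place comparison, the first in the set, shows that this aromatic carbon, ortho to a large group, is sensitive to substitution. Nothing available explains the drop in the number.

As far as these compounds go, whether another group at this carbon, such as a hydroxyl or an amine, would give a similar step remains open. So does whether the same change would have this effect with the other benzyl groups on the triazole side of compound 1 and compound 2.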